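Chloro Added to the Aromatic Ring of Compound 3

This account rests on a few compounds, and the source may have more. Where it says the series, first, only, none or still open, it means among the compounds named here.

Of the compounds shown here, three sharing one core have been tested in a functional assay for inhibition of sulfonylurea receptor 1, Kir6.2 (Homo sapiens); a higher number here means that more compound is needed for the effect, a lower number that less compound is needed. Compound 3 `O=S1(=O)N=C(NC2CCC2)Nc2ccccc21` carries no group on its six-membered aromatic ring of carbon only and gives 1960 nM. That places it second highest of the three numbers: compound 1 `O=[N+]([O-])c1ccc2c(c1)S(=O)(=O)NC(NC1CCC1)=N2`, with a nitro group on that ring, gives 530 nM, while compound 2 `Nc1ccc2c(c1)S(=O)(=O)NC(NC1CCC1)=N2`, with an amino group, gives 31000 nM. Among the compounds with values here, the one step measured between neighbours, a 58-fold higher number from compound 1 to compound 2 (1.77 log units; beyond the scatter), shows that exchanging one group for another on this ring can shift the number a long way.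

Compound 4 `O=S1(=O)N=C(NC2CCC2)Nc2ccc(Cl)cc21` differs from compound 3 by a single change: chloro in place of hydrogen on an aromatic carbon. Within the data shown here, no measured pair shows a chloro group entering or leaving, so the nitro-to-amino step is the only guide, and it bears on compound 4 only loosely, since chloro is a different group placed differently. A small chlorine on an otherwise bare ring is, by the values of compound 1 and compound 3, more likely to lower than to raise the number, though a change within the scatter is possible.

Compound 4 is therefore estimated at 900 nM in this assay, within 250 nM to 3500 nM, an expected step of a 2.2-fold lower number from compound 3 to compound 4 (0.34 log units; beyond the scatter).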

Compound 4, half-maximal effective concentration: 196 nM
The estimate for compound 4 lay 4.6-fold (0.66 log units) above the measured number, outside the stated range (below it).
By their numbers in this assay, from the lowest: compound 4; then compound 1; then compound 3; then compound 2.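

In this assay, chloro in place of hydrogen on the bare aromatic ring gives a 10-fold lower number from compound 3 to compound 4 (1.00 log units; beyond the scatter), a step beyond the usual scatter of the measurements. Within the data shown here, the earlier compounds showed only that exchanging one group for another on this ring can move the number; this is the first pair here to set a substituted ring directly against its unsubstituted counterpart, and it shows that adding a group at this carbon, which is meta to a fused ring on one side and para to a fused ring on the other, can by itself bring the number down. Nothing available explains why chloro has this effect, so the step remains an observation without a known cause.

The compounds shown leave open whether the step belongs to chloro in particular or would also appear with a fluoro, bromo, methyl or methoxy group on the same carbon. They also leave open whether chloro on one of the other carbons of this ring would shift the number in the same direction or by a similar amount.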